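The source may report more compounds than this note shows. Statements on the series, on what has been measured and on what is new or still open speak of the compounds shown alone.

In a functional assay on MCF7 cells (Homo sapiens) for inhibition, read by MTT assay, with stated times of 18 h and 4 h (on this read-out higher numbers stand for weaker inhibition and lower numbers for stronger inhibition), compound 1 `CCCCCCCCOP(=O)(O)OCCSC(=S)N1CCCCCC1` gives 78000 nM. Compound 2 `CCCOP(=O)(O)OCCSC(=S)N1CCCCCC1` gives 74000 nM. Compound 3 `CCCCCCOP(=O)(O)OCCSC(=S)N1CCCCCC1` gives 55000 nM.

Compound 1 has the highest of the three numbers, yet its steps to both other compounds lie within the scatter: a 1.1-fold lower number from compound 1 to compound 2 (0.02 log units; within the scatter) and a 1.4-fold lower number from compound 1 to compound 3 (0.15 log units; within the scatter). The remaining step, a 1.3-fold lower number from compound 2 to compound 3 (0.13 log units; within the scatter), also stays within the scatter. So the three measured compounds are not separated by anything the measurement can resolve.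

Compound 4 `CCCCCCCCOP(=O)(O)OCCSC(=S)N1CCCC1` differs from compound 1 in one place: pyrrolidin-1-yl in place of azepan-1-yl on a thiocarbonyl carbon. Within the data shown here, none of the measured steps touches this part of the molecule; each of them alters only the alkyl chain, and each stays within the scatter. Among the measured compounds shown here, no measured step therefore bears directly on this change, and the data give no ground for a direction. The expectation is a step in this assay that does not exceed the scatter. Compound 4 is accordingly estimated at 78000 nM, within a range from 30000 nM to 200000 nM. That estimate corresponds to an expected step of no change at the digits printed from compound 1 to compound 4 (within the scatter).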

Compound 4, half-maximal inhibitory concentration: 53000 nM
Compound 4: middle estimate off by 1.5-fold (0.17 log units), on the high side, and the stated range covers the measured number.
By their numbers in this assay, from the lowest: compounds 4, 3, 2 and 1 (each within the scatter of the next).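

Among these compounds, compound 4 is the first compound here that changes the ring on the thiocarbonyl carbon rather than the alkyl chain, and in this assay pyrrolidin-1-yl in place of azepan-1-yl gives a 1.5-fold lower number from compound 1 to compound 4 (0.17 log units; within the scatter). A five-membered ring and a seven-membered ring at this position therefore cannot be told apart by this measurement, so for now this part of the molecule, like the chain, shows no resolved effect on the read-out. Nothing available explains the result or tests what lies behind it.

Going by these compounds, it remains open whether a group of another kind on the thiocarbonyl carbon, such as morpholin-4-yl or an open-chain diethylamino group, would give a step beyond the scatter. On these data alone, it is also open whether pyrrolidin-1-yl would give the same picture on the alkyl chains of compound 2 and compound 3.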